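Swapping tert-butyl for phenyl on compound 3

A few compounds are considered here, and "the series" means these few. Any claim that something is new, unique, unknown or untested is made for them only; others in the source may bear on it.

Three compounds have been read so far in an ADME assay on liver for metabolic stability, with Liver microsome (Homo sapiens) as the target, read by LC-MS, using microsomes (a higher number here means faster removal of the compound, a lower number slower removal), as follows:

Compound 1 `CC(C)(C)[C@@H](O)C(=O)N1C[C@@H]2C[C@@H]2[C@H]1C(=O)NCc1cc(Cl)ccc1-n1cnnn1` gives < 15 mL.min-1.g-1 as a limit.
Compound 2 `CC(C)(C)[C@@H](O)C(=O)N1N=CC[C@H]1C(=O)NCc1cc(Cl)ccc1-n1cnnn1` gives < 12 mL.min-1.g-1 as a limit.
Compound 3 `CC(C)(C)[C@@H](O)C(=O)N1C[C@H]2C[C@H]2[C@H]1C(=O)NCc1cc(Cl)ccc1-n1cnnn1` gives 22 mL.min-1.g-1 as a number.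

Among the measured compounds shown here, compound 3 thus holds the only true number in this set, and the other two values are limits. Compound 4 `O=C(NCc1cc(Cl)ccc1-n1cnnn1)[C@@H]1[C@@H]2C[C@@H]2CN1C(=O)[C@H](O)c1ccccc1` has not yet been measured. It differs from compound 3 by phenyl in place of tert-butyl on a saturated chain carbon bound to a carbonyl carbon and an oxygen on a saturated carbon in one place: phenyl in place of tert-butyl on a saturated chain carbon bound to a carbonyl carbon and an oxygen on a saturated carbon.

For the measured compounds named here, the sole measured step is an at least 1.4-fold higher number from compound 1 to compound 3 (0.16 log units; that floor lies within the scatter) and it rests on the fact that compounds 1 and 3 differ only in the configuration as drawn alone. Going by the values given here, that step leaves the tert-butyl in place, so it gives no size for this exchange, and no measured pair changes that group. With no direction to go on, no large step is expected in this assay and the expectation stays close to compound 3 at 22 mL.min-1.g-1 with a wide margin. The estimated step is a 1.1-fold higher number from compound 3 to compound 4 (0.04 log units; within the scatter) on this reckoning. For compound 4 the estimate is 24 mL.min-1.g-1 with 11 mL.min-1.g-1 to 52 mL.min-1.g-1 as its expected range.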

Compound 4, intrinsic clearance in microsomes: < 15 mL.min-1.g-1
Compound 4 was reported as a limit; the forecaster's own chance of this, stated with the estimate: 25%; middle value at least 1.6-fold (0.20 log units) away from the limit.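

Among the compounds shown here, this is the first measured change of the group on a saturated chain carbon bound to a carbonyl carbon and an oxygen on a saturated carbon, and in this assay it gives an at least 1.4-fold lower number from compound 3 to compound 4 (0.16 log units; that floor lies within the scatter). The earlier compounds shown here kept tert-butyl at this place, so they gave no reading of this exchange; now the step has a direction, but only a floor for its size, and that floor does not settle whether the true gap exceeds the usual scatter. Compound 4 is reported only as a limit, not as a number, and that limit recurs in this small set: the limit of < 15 mL.min-1.g-1 in this assay, at which 2 of the 4 values shown sit.

On these data alone, how far the true value of compound 4 lies from that of compound 3 therefore stays open, and so does whether the same exchange would read alike on the cores of compound 1 or compound 2. The compounds shown also leave open how a cyclohexyl ring, a pyridine ring or an isopropyl group at this place would read in this assay.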